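Phenyl to tert-Butyl on the Amide Nitrogen

This account rests on a few compounds, and the source may have more. Where it says the series, first, only, none or still open, it means among the compounds named here.

Compound 1 `C=CC1=C(C(=O)Nc2ccccc2)C(c2ccc(Cl)c(Cl)c2)OC1`: > 100000 nM
Compound 2 `C=CC1=C(C(=O)Nc2ccccc2)C(c2ccc(F)cc2)OC1`: 46700 nM

Going by the values given here, in a functional assay on QGY7701 cells (Homo sapiens) for cytotoxicity, read by MTT assay, with a stated time of 24 h (on this read-out lower numbers stand for stronger inhibition and higher numbers for weaker inhibition), compound 2 gives 46700 nM, the only plain number among the two compounds. Compound 1 shows > 100000 nM, which is the limit of > 100000 nM in this assay, at which 1 of the 2 values shown sits, rather than a number. Compound 3 `C=CC1=C(C(=O)NC(C)(C)C)C(c2ccc(F)cc2)OC1` differs from compound 2 by tert-butyl in place of phenyl on an amide-type nitrogen. The single measured step, an at least 2.1-fold lower number from compound 1 to compound 2 (0.33 log units; beyond the scatter), concerns the aromatic ring on the saturated ring carbon, not the amide nitrogen, so it does not bear on this change, and no other comparison shown touches the amide substituent. With nothing measured of this kind, the expected outcome is a step within the scatter, which for the move from compound 2 to compound 3 is estimated as a 1.2-fold higher number from compound 2 to compound 3 (0.07 log units; within the scatter). Compound 3 is accordingly estimated at 55000 nM, with a range from 18000 nM to 170000 nM, and a real chance that this assay returns only a limit.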

Compound 3, half-maximal inhibitory concentration: > 100000 nM
Compound 3 was reported as a limit; the forecaster's own chance of this, stated with the estimate: 30%; middle value at least 1.8-fold (0.25 log units) away from the limit.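

In this assay, tert-butyl in place of phenyl on the amide-type nitrogen gives an at least 2.1-fold higher number from compound 2 to compound 3 (0.33 log units; beyond the scatter). The earlier step concerned only the aromatic ring on the saturated ring carbon, whereas this one shows that the group on the amide nitrogen also matters for this read-out, and that phenyl there does better than tert-butyl. Compound 3 gives > 100000 nM, which is a limit and not a number, and with it only compound 2 keeps a plain value: the limit of > 100000 nM in this assay, at which 2 of the 3 values shown sit.

On these data alone, it remains open whether a cyclohexyl ring, a benzyl group or a 4-methoxyphenyl group on the same nitrogen would hold or lower the number seen for compound 2. Compound 1 and compound 3 differ in more than one place, and they cannot be ranked against each other.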